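This account rests on a few compounds, and the source may have more. Where it says the series, first, only, none or still open, it means among the compounds named here.

Compound 1 `COc1cc(/C=C/C(=O)/C=C/c2nc3ccccc3n2C)ccc1O` gives 4700 nM in a functional assay on SH-SY5Y cells (Homo sapiens) for cytotoxicity, read by MTT assay, with a stated time of 48 h; on this read-out lower numbers stand for stronger inhibition and higher numbers for weaker inhibition.
Compound 2 `COc1cc(/C=C/C(=O)/C=C/c2nc3c(C)cccc3n2C)ccc1O` gives 1000 nM.
Compound 3 `COc1ccc2c(c1)nc(/C=C/C(=O)/C=C/c1ccc(O)c(OC)c1)n2C` gives 4800 nM.

Among these three numbers compound 1 stands second highest. Compound 3 sits within the scatter of it, the step being a 1.0-fold higher number from compound 1 to compound 3 (0.01 log units; within the scatter), while compound 2 is set apart by a 4.7-fold lower number from compound 1 to compound 2 (0.67 log units; beyond the scatter), a modest step. Compound 4 `COc1cc(/C=C/C(=O)/C=C/c2nc3cc(Cl)ccc3n2C)ccc1O` differs from compound 1 by chloro in place of hydrogen on an aromatic carbon. Both measured steps alter an aromatic carbon of the same core: methyl gave the modest lowering seen in compound 2, methoxy gave no change beyond scatter in compound 3. Neither tells of chloro directly, so only a small step, if any, is expected. Compound 4 is therefore estimated at 3200 nM, within 1300 nM to 8000 nM, meaning an expected step of a 1.5-fold lower number from compound 1 to compound 4 (0.17 log units; within the scatter).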

Compound 4, half-maximal inhibitory concentration: 4700 nM
Estimate against measurement, compound 4: 1.5-fold (0.17 log units) below; the measured number falls inside the stated range.
By their numbers in this assay, from the lowest: compound 2; then compounds 1, 4 and 3 (each within the scatter of the next).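

In this assay, chloro on this aromatic carbon gives no change at the digits printed from compound 1 to compound 4 (within the scatter) and, set against methoxy on the same carbon, gives a 1.0-fold lower number from compound 3 to compound 4 (0.01 log units; within the scatter) in the same range. Hydrogen, methoxy and chloro thus read alike at this one position, while the methyl of compound 2 stands on a different carbon of the ring. No measured evidence is available to explain this flat result. Still open, going by these compounds, is whether an amine or a carboxylic acid on this carbon would also leave the number unmoved, and whether methyl here would match compound 2.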